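The compounds below may be only part of what the source reports. "The series", "measured", "known", "first", "only" and "open" are said of these compounds alone.

Measured so far:
compound 1, `O=C(c1ccccc1)c1sc(N2CCCC2)nc1Br` — > 100000 nM
compound 2, `O=C(c1ccccc1)c1sc(N2CCCCC2)nc1Br` — 62000 nM
compound 3, `COC(=O)c1sc2nc(N3CCCC3)sc2c1C` — > 100000 nM

All three were tested in a functional assay on PC-3 cells (Homo sapiens) for cytotoxicity, read by MTT assay, with a stated time of 72 h; a higher number here means a weaker inhibitor, a lower number a stronger inhibitor. For compound 1 the value > 100000 nM is a limit of the assay and not a number. Compound 2 gives 62000 nM in this assay. Between these two the change is piperidin-1-yl in place of pyrrolidin-1-yl on an aromatic carbon, and it brings an at least 1.6-fold lower number from compound 1 to compound 2 (0.20 log units; that floor lies within the scatter). That step is known only as a floor because the limit of > 100000 nM in this assay, at which 2 of the 3 values shown sit, caps what compound 1 can show.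

Compound 3 belongs to a different core, and the difference between the two cores is not broken down here. For compound 3 the value > 100000 nM is again a limit of the assay and not a number. Compound 4, `COC(=O)c1sc2nc(N3CCCCC3)sc2c1C`, has not been measured; it differs from compound 3 by piperidin-1-yl in place of pyrrolidin-1-yl on an aromatic carbon. Going by the values given here, this is the same kind of change as the one from compound 1 to compound 2, though the surroundings are not identical: in compound 1 the place lies two ring bonds from the ring atom that bears a bromo group and two ring bonds from the ring atom that bears a group of 8 heavy atoms, whereas in compound 3 the ring is part of a fused or bridged system of two rings.

Since compound 3 starts at the limit, the step from compound 3 to compound 4 is expected to be about an at least 1.1-fold lower number from compound 3 to compound 4 (0.04 log units; that floor lies within the scatter) in this assay, resting on the floor seen from compound 1 to compound 2. Compound 4 is therefore estimated at 90000 nM, most likely between 30000 nM and 300000 nM.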

Compound 4, half-maximal inhibitory concentration: 93000 nM
Compound 4: the middle estimate sits 1.0-fold (0.01 log units) below what was measured, and the stated range covers the measured number.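

In this assay, putting piperidin-1-yl in place of pyrrolidin-1-yl on the core of compound 3 brings an at least 1.0-fold lower number from compound 3 to compound 4 (0.03 log units; that floor lies within the scatter). This shows that the change can be made on a second core and that the larger ring gives a measurable number there, but both steps are only floors within the scatter, so neither core shows a clear gain, and whether the change acts the same way on the two cores stays unsettled: the same change on two cores in this assay, an at least 1.6-fold lower number (0.20 log units; that floor lies within the scatter) from compound 1 to compound 2 and an at least 1.0-fold lower number (0.03 log units; that floor lies within the scatter) from compound 3 to compound 4; the limit leaves it open whether they differ The true size of each step cannot be read because compound 1 and compound 3 each start from a limit of the assay and not from a number: the limit of > 100000 nM in this assay, at which 2 of the 4 values shown sit.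

The compounds shown leave open whether any other amine on that aromatic carbon, such as morpholine or an open-chain dimethylamino group, would give a step that can be read clearly on either core. They also leave open how a carboxylic acid or an amide in place of the methyl ester on the core of compound 4 would read in this assay.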